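From 2-methylpyrimidin-5-yl to 2-propylpyrimidin-5-yl: clearance at the limit

The source may report more compounds than this note shows. Statements on the series, on what has been measured and on what is new or still open speak of the compounds shown alone.

Of the compounds shown here, two have been measured, compound 1 (`CCOc1ncc(-c2nc(C(F)(F)F)sc2N2CCN(C(=O)Cn3nc(C)nc3C)[C@H](C)C2)cn1`) and compound 2 (`Cc1ncc(-c2nc(C(F)(F)F)sc2N2CCN(C(=O)Cn3nc(C)nc3C)[C@H](C)C2)cn1`). In a toxicity assay on microsomes from liver (Homo sapiens) for metabolic stability, read by LC-MS, using NADPH, tested at 1 uM (a lower number here means slower removal, a higher number faster removal of the compound), compound 1 gives < 10 mL.min-1.g-1, which is a limit and not a number. In this assay compound 2 gives < 10 mL.min-1.g-1, again a limit. Compound 2 therefore has no readable number, and the evidence so far is the limit of < 10 mL.min-1.g-1 in this assay, at which 2 of the 2 values shown sit.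

Compound 3 (`CCCc1ncc(-c2nc(C(F)(F)F)sc2N2CCN(C(=O)Cn3nc(C)nc3C)[C@H](C)C2)cn1`) differs from compound 2 by ethyl in place of hydrogen on a saturated chain carbon bound to an aromatic carbon, which turns methyl into propyl. Among the compounds with values here, the only measured step that bears on this is a step that the two limits leave unreadable from compound 1 to compound 2, with methyl in place of ethoxy on an aromatic carbon, and it offers no size to carry over. Within the data shown here, no measured step covers a propyl group. Given a step that the two limits leave unreadable from compound 1 to compound 2, the expectation in this assay is a small move toward faster removal or none beyond the scatter. The estimated step is an at least 1.1-fold higher number from compound 2 to compound 3 (0.04 log units; that floor lies within the scatter). For compound 3 the expected value is 11 mL.min-1.g-1, with an estimated range of 6 mL.min-1.g-1 to 25 mL.min-1.g-1.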

Compound 3, intrinsic clearance in microsomes: 80 mL.min-1.g-1
For compound 3 the middle estimate is 7.3-fold (0.86 log units) below the measured one, and the stated range ends below it.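

The 2-substituent on the pyrimidine is not a silent position in this assay, as the earlier pair suggested: ethyl in place of hydrogen on a saturated chain carbon bound to an aromatic carbon, which turns methyl into propyl, gives an at least 8.0-fold higher number from compound 2 to compound 3 (0.90 log units; beyond the scatter). The second readable step is an at least 8.0-fold higher number from compound 1 to compound 3 (0.90 log units; beyond the scatter), so compound 3 separates from both earlier compounds, and a modest enlargement of this substituent is enough to give a number well clear of the limit, while the step between the two limits themselves cannot be read. Both readable steps are floors and not sizes, and the true step may be larger: the limit of < 10 mL.min-1.g-1 in this assay, at which 2 of the 3 values shown sit.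

Open, from the compounds shown here alone, is where between methyl and propyl the rise in clearance sets in, and whether it continues with a longer chain such as butyl or depends on chain shape, as an isopropyl or cyclopropyl group at this place would show. Also open, going by these compounds, is whether a hydroxyl or an amine on the propyl chain would return the clearance to the level of the limit.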